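Compound 3: carboxy in place of 2-azidoethyl

This account rests on a few compounds, and the source may have more. Where it says the series, first, only, none or still open, it means among the compounds named here.

Compound 1 `COc1ccc(C[C@H]2C(=O)N[C@@H](C)C(=O)N(C)[C@H]3Cc4ccc(cc4)Oc4cc(ccc4OC)C[C@@H](C(=O)N[C@H](C)C(=O)N[C@@H](CCCO)C(=O)N2C)N(C)C3=O)cc1` gives 174 nM in a functional assay on P388 cells (Mus musculus) for cytotoxicity; a lower number here means a stronger inhibitor, a higher number a weaker inhibitor
Compound 2 `COc1ccc(C[C@H]2C(=O)N[C@@H](C)C(=O)N(C)[C@H]3Cc4ccc(cc4)Oc4cc(ccc4OC)C[C@@H](C(=O)N[C@H](C)C(=O)N[C@@H](CCCN=[N+]=[N-])C(=O)N2C)N(C)C3=O)cc1` gives 35.5 nM in this assay

Compound 2 at 35.5 nM holds the lower of the two numbers in this assay and is the starting point here. Compound 3 `COc1ccc(C[C@H]2C(=O)N[C@@H](C)C(=O)N(C)[C@H]3Cc4ccc(cc4)Oc4cc(ccc4OC)C[C@@H](C(=O)N[C@H](C)C(=O)N[C@@H](CC(=O)O)C(=O)N2C)N(C)C3=O)cc1` has carboxy in place of 2-azidoethyl on a saturated chain carbon bound to a saturated ring carbon and awaits measurement. Among the measured compounds shown here, the one measured step that bears on this, a 4.9-fold lower number from compound 1 to compound 2 (0.69 log units; beyond the scatter) with azido in place of hydroxy, was modest but beyond the scatter. For the measured compounds named here, no measured compound carries carboxy, so the inference is loose. Losing the azido group is expected to move the number back toward compound 1 at 174 nM or somewhat past it. The expected change is an 8.5-fold higher number from compound 2 to compound 3 (0.93 log units; beyond the scatter) in this assay for this pair. Compound 3 is estimated at 300 nM in this assay with an expected range from 60 nM to 1500 nM in this read-out.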

Compound 3, half-maximal inhibitory concentration: 1200 nM
Estimate against measurement, compound 3: 4.0-fold (0.60 log units) below; measured number inside the range.
By their numbers in this assay, from the lowest: compound 2; then compound 1; then compound 3.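

In this assay, the change to carboxymethyl moves the number upward against both other compounds (a 34-fold higher number from compound 2 to compound 3 (1.53 log units; beyond the scatter)) and (a 6.9-fold higher number from compound 1 to compound 3 (0.84 log units; beyond the scatter)), so compound 3 has the highest number of the three. The position therefore spans a wider range than the azido-for-hydroxy step showed. Nothing given here accounts for this rise.

Carboxymethyl differs from 3-azidopropyl in both chain length and end group, so the compounds shown cannot separate those two changes. Going by these compounds, how a carboxylic acid on a propyl chain, or an amine there, would read remains open.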